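A Second Fluoro on the Phenyl Ring of Compound 3

The source may hold more compounds than are shown below. What is called first, only, known or untested is meant among the compounds shown, and "the series" means these compounds.

compound 1 `N=C(NCCCc1c[nH]cn1)NCCC(c1ccc(Br)cc1)c1ccccn1` gives 0.4
compound 2 `N=C(NCCCc1c[nH]cn1)NCCC(c1ccc(C(F)(F)F)cc1)c1ccccn1` gives 0.9
compound 3 `N=C(NCCCc1c[nH]cn1)NCCC(c1cccc(F)c1)c1ccccn1` gives 0.5

In a functional assay on muscle tissue for agonist activity at histamine H2 receptor (Cavia porcellus) (a lower number here means a smaller maximal response, a higher number a larger maximal response), compound 3 stands second highest of the three measured compounds: a number 0.10 higher from compound 1 to compound 3 (within the scatter) lies within the scatter, while a number 0.40 lower from compound 2 to compound 3 (beyond the scatter) lies well beyond it. Compound 4 `N=C(NCCCc1c[nH]cn1)NCCC(c1cc(F)cc(F)c1)c1ccccn1` differs from compound 3 by fluoro in place of hydrogen on an aromatic carbon. Going by the values given here, none of the measured steps replaces a hydrogen on the phenyl ring with a fluoro group; the measured steps either exchange the whole aryl group or exchange bromo for trifluoromethyl, as in a number 0.50 higher from compound 1 to compound 2 (beyond the scatter). Of the steps touching compound 3, the exchange of one aryl group for another with a single fluoro, a number 0.10 higher from compound 1 to compound 3 (within the scatter), changed the intrinsic activity little, whereas a number 0.40 lower from compound 2 to compound 3 (beyond the scatter) was large. Among the compounds with values here, the data hold no step of the same kind as the one from compound 3 to compound 4, so only a small step, no change at the digits printed from compound 3 to compound 4 (within the scatter), is expected in this assay, with no direction beyond the scatter. Compound 4 is estimated at 0.5, within the range 0.3 to 0.8.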

Compound 4, intrinsic activity: the largest response reached, as a fraction of the reference agonist's: 0.8
Compound 4: the middle estimate sits 0.30 below what was measured; the range from low to high includes it.
By their numbers in this assay, from the lowest: compounds 1 and 3 (each within the scatter of the next); then compounds 4 and 2 (each within the scatter of the next).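

In this assay, replacing a hydrogen on the phenyl ring with a fluoro group, on an aromatic carbon meta to a fluoro group, gives a number 0.30 higher from compound 3 to compound 4 (beyond the scatter) and so shows that this position responds to a single added fluorine. The 3,5-difluorophenyl group also gives a number 0.10 lower from compound 2 to compound 4 (within the scatter) against 4-(trifluoromethyl)phenyl and a number 0.40 higher from compound 1 to compound 4 (beyond the scatter) against 4-bromophenyl, so among these compounds a response in the range of compound 2 does not require trifluoromethyl. Nothing measured here accounts for the step from hydrogen to fluoro.

On these data alone, it remains open whether a chloro or a methoxy group on the same aromatic carbon would raise the response as fluoro does. As far as these compounds go, it is also open whether the rise depends on the fluoro group already on the ring.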